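The source may report more compounds than this note shows. Statements on the series, on what has been measured and on what is new or still open speak of the compounds shown alone.

Measured in an ADME assay on cells (Hepatocyte, Homo sapiens) for metabolic stability; a lower number here means that the compound disappears faster, a higher number that the compound lasts longer:
compound 1 `O=C(Nc1ccc(F)c(Cl)c1)c1ccc(F)c(S(=O)(=O)N2C[C@H](O)CC[C@H](O)C2)c1` 8.58 h
compound 2 `O=C(Nc1ccc(F)c(Cl)c1)c1ccc(F)c(S(=O)(=O)N2CCOCC(O)C2)c1` 4.63 h
compound 3 `CC1(O)COCCN(S(=O)(=O)c2cc(C(=O)Nc3ccc(F)c(Cl)c3)ccc2F)C1` 1.28 h

Compound 3 has the lowest number of the three. The next step leads to compound 4 `O=C(Nc1ccc(F)c(Cl)c1)c1ccc(F)c(S(=O)(=O)N2CCCCC(O)C2)c1` with 3-hydroxyazepan-1-yl in place of 6-hydroxy-6-methyl-1,4-oxazepan-4-yl on a sulfonyl sulfur. Going by the values given here, two measured steps bear on it. Adding the methyl gave a 3.6-fold lower number from compound 2 to compound 3 (0.56 log units; beyond the scatter), and compound 4 carries no methyl. The ring exchange gave a 1.9-fold lower number from compound 1 to compound 2 (0.27 log units; within the scatter). Among the compounds with values here, no measured compound carries 3-hydroxyazepan-1-yl, so reversing the methyl step is only a rough guide. A modest rise in this assay is therefore expected, of similar size to the methyl step. The expected step is a 2.3-fold higher number from compound 3 to compound 4 (0.37 log units; beyond the scatter). The estimate for compound 4 is 3 h (1 h to 8 h).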

Compound 4, half-life: 0.817 h
Beside the measured number, compound 4's estimate is 3.7-fold (0.56 log units) above it, outside the stated range (below it).
By their numbers in this assay, from the lowest: compounds 4 and 3 (each within the scatter of the next); then compounds 2 and 1 (each within the scatter of the next).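

On the sulfonyl sulfur, 3-hydroxyazepan-1-yl in place of 3,6-dihydroxyazepan-1-yl gives an 11-fold lower number from compound 1 to compound 4 (1.02 log units; beyond the scatter) in this assay and is the largest step in the series, so the second hydroxyl of compound 1 matters here, while the seven-membered carbon ring alone does not preserve the half-life. Against the ring oxygen of 6-hydroxy-1,4-oxazepan-4-yl the change gives a 5.7-fold lower number from compound 2 to compound 4 (0.75 log units; beyond the scatter), whereas against 6-hydroxy-6-methyl-1,4-oxazepan-4-yl it gives a 1.6-fold lower number from compound 3 to compound 4 (0.19 log units; within the scatter). Nothing available explains these steps.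

Going by these compounds, whether an amine, a methoxy group or a fluorine in place of the second hydroxyl of 3,6-dihydroxyazepan-1-yl would keep the number of compound 1 stays open.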